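Dropping the chloro from compound 2: expected cytotoxicity

This account rests on a few compounds, and the source may have more. Where it says the series, first, only, none or still open, it means among the compounds named here.

Measured compounds:
- compound 1, `CNC(=O)c1cc(Oc2ccc(C3=NNC(c4ccc(C#N)cc4)C3)cc2)ccn1`: 17400 nM
- compound 2, `CNC(=O)c1cc(Oc2ccc(C3=NNC(c4ccc(F)cc4Cl)C3)cc2)ccn1`: 13700 nM
- compound 3, `CNC(=O)c1cc(Oc2ccc(C3=NNC(c4cccc([N+](=O)[O-])c4)C3)cc2)ccn1`: "not determined" (no result reported)

The series was tested in a functional assay on A549 cells (Homo sapiens) for cytotoxicity, read by MTT assay, with a stated time of 72 h; on this read-out lower numbers stand for stronger inhibition and higher numbers for weaker inhibition. Among the measured compounds shown here, compound 2 stands as the lowest of the two numbers, with compound 1 nearest; the only measured step, a 1.3-fold lower number from compound 1 to compound 2 (0.10 log units; within the scatter), is within the scatter, so no order between the two can be read.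

Compound 4, `CNC(=O)c1cc(Oc2ccc(C3=NNC(c4ccc(F)cc4)C3)cc2)ccn1`, differs from compound 2 by hydrogen in place of chloro on an aromatic carbon. For the measured compounds named here, no measured step touches this position, and the one step that does exist, between compound 1 and compound 2, exchanges the whole aryl group without moving the number beyond the scatter. Nothing in the data therefore points to a change of size in either direction. The expected step of a 1.0-fold higher number from compound 2 to compound 4 (0.01 log units; within the scatter) is accordingly none beyond the scatter. Compound 4 is estimated to give 14000 nM in this assay, with a range from 5000 nM to 40000 nM, resting on compound 2 because compound 2 gives 13700 nM.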

Compound 4, half-maximal inhibitory concentration: 15100 nM
Compound 4: middle estimate off by 1.1-fold (0.03 log units), on the low side; the range from low to high includes it.
By their numbers in this assay, from the lowest: compounds 2, 4 and 1 (each within the scatter of the next).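

With this assay as the read-out, removing the chloro group leaves 4-fluorophenyl in place of 2-chloro-4-fluorophenyl and gives a 1.1-fold higher number from compound 2 to compound 4 (0.04 log units; within the scatter) as its step. Among the compounds shown here, for the first time this isolates the position ortho to a large group and meta to a fluoro group, and chloro and hydrogen cannot be told apart there. The step of a 1.2-fold lower number from compound 1 to compound 4 (0.06 log units; within the scatter) likewise shows no readable difference between fluoro and cyano on an aromatic carbon, and no measurement shown bears on why these numbers stay so close.

On these data alone, whether an amine or a carboxylic acid at the chloro position would move the number beyond the scatter stays open. The same question stands for a longer chain in place of the fluoro group.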